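Compound 4: a bromo group on the weakest compound

The source may report more compounds than this note shows. Statements on the series, on what has been measured and on what is new or still open speak of the compounds shown alone.

In a functional assay on L1210 cells (Mus musculus) for antiproliferative activity, with a stated time of 48 h (a higher number here means a weaker inhibitor, a lower number a stronger inhibitor), compound 3 (`Nc1ccc(/C=C/C(=O)c2ccccc2)cc1`) gives 88000 nM, the highest number of the three measured. Compound 1 (`C=C(Br)C(=O)Nc1ccc(/C=C/C(=O)c2ccccc2)cc1`) gives 5000 nM, and compound 2 (`C=C(Br)C(=O)Nc1ccc(C(=O)/C=C/c2cc(OC)c(OC)c(OC)c2)cc1`) gives 1500 nM. Compound 4 (`Nc1ccc(/C=C/C(=O)c2ccc(Br)cc2)cc1`) differs from compound 3 in one place: bromo in place of hydrogen on an aromatic carbon. Among the measured compounds shown here, the only measured step is an 18-fold higher number from compound 1 to compound 3 (1.25 log units; beyond the scatter), a large one, but it concerns a (1-bromoethenyl)carbonyl on a nitrogen, not a bromo on an aromatic carbon. For the measured compounds named here, no measured step covers the new change, so no step beyond the scatter is expected in this assay. The expected step is a 1.5-fold lower number from compound 3 to compound 4 (0.17 log units; within the scatter). The estimate for compound 4 is 60000 nM, with an expected range of 20000 nM to 120000 nM.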

Compound 4, half-maximal inhibitory concentration: 90000 nM
Estimate against measurement, compound 4: 1.5-fold (0.18 log units) below, and the stated range covers the measured number.
By their numbers in this assay, from the lowest: compound 2; then compound 1; then compounds 3 and 4 (each within the scatter of the next).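

In this assay, a bromo group in place of hydrogen on this aromatic carbon, para to a large group, gives a number that cannot be told apart from that of the parent: a 1.0-fold higher number from compound 3 to compound 4 (0.01 log units; within the scatter). Among the compounds shown here, the earlier step concerned the nitrogen; this is the first reading at this ring carbon, and here a single bromine atom leaves the result within the scatter. Nothing available explains this result.

From the compounds shown here alone, whether a methoxy group, a hydroxyl group or a carboxylic acid on this same carbon would read alike remains open. So does whether bromo here would read the same in compound 1, which carries the (1-bromoethenyl)carbonyl on its nitrogen.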